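Swapping the tetrazole for a pyrimidine in compound 1

The compounds below may be only part of what the source reports. "The series", "measured", "known", "first", "only" and "open" are said of these compounds alone.

Measured compounds:
compound 1, `Cn1nnnc1SCC(=O)N/N=c1/scc(-c2ccc(F)cc2)n1-c1ccccc1`, 113 ug/mL
compound 2, `Cn1nnnc1SCC(=O)N/N=c1/scc(-c2ccc(Br)cc2)n1-c1ccccc1`, 19.3 ug/mL
compound 3, `Cn1nnnc1SCC(=O)N/N=c1/scc(-c2ccc(Cl)cc2)n1-c1ccccc1`, 40 ug/mL

Three compounds share a core and differ only in the halogen on one aromatic ring. In an ADME assay on NIH3T3 cells (Mus musculus) for cytotoxicity, read by MTT assay, with a stated time of 24 h (a lower number here means a stronger inhibitor, a higher number a weaker inhibitor), compound 1 gives 113 ug/mL, the highest of the three numbers. The nearest is compound 3, reached by a 2.8-fold lower number from compound 1 to compound 3 (0.45 log units; beyond the scatter), and the furthest is compound 2, reached by a 5.9-fold lower number from compound 1 to compound 2 (0.77 log units; beyond the scatter); between those two, a 2.1-fold higher number from compound 2 to compound 3 (0.32 log units; beyond the scatter) separates them.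

Compound 4, `O=C(CSc1ncccn1)N/N=c1/scc(-c2ccc(F)cc2)n1-c1ccccc1`, has not yet been measured in this assay. Relative to compound 1 the change is pyrimidin-2-yl in place of 1-methyl-1H-tetrazol-5-yl on a sulfur. The fluoro on the aromatic ring is kept, so the halogen steps among compounds 1, 2 and 3 do not speak to this change: every measured step concerns a halogen on an aromatic carbon, and none alters the group on the sulfur. Within the data shown here, there is therefore no measured step that bears on the move from compound 1 to compound 4, and the expectation must rest on compound 1 alone.

With no guidance from the measured steps, compound 4 is expected to stay close to compound 1, with an estimated step of a 1.0-fold lower number from compound 1 to compound 4 (0.01 log units; within the scatter), not beyond the scatter. The estimate for compound 4 is 110 ug/mL, within a range of 45 ug/mL to 270 ug/mL.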

Compound 4, half-maximal inhibitory concentration: > 500 ug/mL
Compound 4 gave a limit, no number; the forecaster's own chance of this, stated with the estimate: 10%; middle value at least 4.5-fold (0.65 log units) away from the limit.
By their numbers in this assay, from the lowest: compound 2; then compound 3; then compound 1. At a limit, above all of these: compound 4.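

The group on the sulfur, which none of the halogen steps touched, proves able to shift the result in this assay: pyrimidin-2-yl in place of 1-methyl-1H-tetrazol-5-yl, with the fluoro kept, gives an at least 4.4-fold higher number from compound 1 to compound 4 (0.64 log units; beyond the scatter). Both halogen steps away from compound 1 lowered the number, whereas this change on the sulfur raises it, so compound 1 is not at the top of the range for this series and the change at this position can move the number in the opposite direction. The reading for compound 4 is a limit and not a number, so the step has a minimum size but no fixed one: the limit of > 500 ug/mL in this assay, at which 1 of the 4 values shown sits.

The compounds shown leave open whether a phenyl, a pyridin-2-yl or a plain methyl on the sulfur would fall nearer compound 1 or compound 4 in this assay. They also leave open whether pyrimidin-2-yl has a similar effect with the bromo of compound 2 or the chloro of compound 3 on the aromatic ring.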